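The source may hold more compounds than are shown below. What is called first, only, known or untested is meant among the compounds shown, and "the series" means these compounds.

Compound 2 `CSc1ccccc1NC(=O)N[C@H]1CC[C@H](Oc2ccc(F)cc2)CC1` belongs to a short series built on one shared core, tested in a functional assay on CRL2813 cells (Homo sapiens) for cytotoxicity, read by sulforhodamine B assay, with a stated time of 5 days; a lower number here means a stronger inhibitor, a higher number a weaker inhibitor. In this assay compound 2 gives > 20000 nM, which is a limit of the assay and not a number. Among the measured compounds shown here, its single measured neighbour, compound 1 `O=C(Nc1ccc(Br)cc1)N[C@H]1CC[C@H](Oc2ccc(F)cc2)CC1`, is likewise recorded only as a limit, giving > 20000 nM in this assay. For the measured compounds named here, the only measured step, a step that the two limits leave unreadable from compound 1 to compound 2, therefore cannot be read in size or direction, since (the limit of > 20000 nM in this assay, at which 2 of the 2 values shown sit). Compound 3 `O=C(Nc1ccccc1[N+](=O)[O-])N[C@H]1CC[C@H](Oc2ccc(F)cc2)CC1` differs from compound 2 by one change: nitro in place of methylsulfanyl on an aromatic carbon. Going by the values given here, no measured step bears readably on this change, so the expectation for compound 3 rests on the two limits alone, and the step that the limit leaves unreadable from compound 2 to compound 3 is expected to stay within the scatter. Compound 3 is estimated at 30000 nM in this assay, with a range from 10000 nM to 100000 nM.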

Compound 3, half-maximal inhibitory concentration: 3500 nM
The estimate for compound 3 lay 8.6-fold (0.93 log units) above the measured number; measured number below the stated range.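

Nitro in place of methylsulfanyl, on an aromatic carbon ortho to a large group, turns a limit into a real number in this assay, with an at least 5.7-fold lower number from compound 2 to compound 3 (0.75 log units; beyond the scatter). Against the 4-bromophenyl of the other neighbour, the 2-nitrophenyl gives an at least 5.7-fold lower number from compound 1 to compound 3 (0.75 log units; beyond the scatter), so compound 3 is the only one of the three that can be placed on the scale, and this substituent position is shown to be able to change the read-out. Both steps are minimum sizes only, since each starts from a limit: the limit of > 20000 nM in this assay, at which 2 of the 3 values shown sit.

The compounds shown leave open whether this gain belongs to the nitro group alone or would also come with an amine, a nitrile or a carboxylic acid on the same carbon. They also leave open whether the 2-nitrophenyl would give a similar number on a core other than the shared one.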